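Replacing the chlorophenyl amide of compound 1 with a pyrrolidine

The source may report more compounds than this note shows. Statements on the series, on what has been measured and on what is new or still open speak of the compounds shown alone.

Compound 1 `O=C(c1ccc(Cl)cc1)N1CCC(NS(=O)(=O)c2cc(S(=O)(=O)c3ccccc3)ccc2C(F)(F)F)CC1` is measured in an assay on isolated protein for displacement of a labelled ligand from secreted frizzled-related protein 1 (Homo sapiens), read by fluorescence polarization, with a stated time of 30 min (a lower number here means a stronger inhibitor, a higher number a weaker inhibitor), where compound 1 gives 300 nM. Among the measured compounds shown here, this is the highest of the three numbers known so far. Compound 2 `O=C(c1cccnc1)N1CCC(NS(=O)(=O)c2cc(S(=O)(=O)c3ccccc3)ccc2C(F)(F)F)CC1` gives 80 nM in the same assay, and compound 3 `O=C(C1CCNCC1)N1CCC(NS(=O)(=O)c2cc(S(=O)(=O)c3ccccc3)ccc2C(F)(F)F)CC1` gives 120 nM. The step of a 3.8-fold lower number from compound 1 to compound 2 (0.57 log units; beyond the scatter) and the step of a 2.5-fold lower number from compound 1 to compound 3 (0.40 log units; beyond the scatter) both exceed the scatter, while the step of a 1.5-fold higher number from compound 2 to compound 3 (0.18 log units; within the scatter) does not.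

Compound 4 `O=C([C@@H]1CCNC1)N1CCC(NS(=O)(=O)c2cc(S(=O)(=O)c3ccccc3)ccc2C(F)(F)F)CC1` has not yet been measured. It differs from compound 1 in one place: pyrrolidin-3-yl in place of 4-chlorophenyl on a carbonyl carbon. For the measured compounds named here, the change most like it among the measured steps is the one from compound 1 to compound 3, where piperidin-4-yl, another saturated ring with one nitrogen and one hydrogen-bond donor, replaced the same 4-chlorophenyl on the carbonyl carbon and the number fell by a modest amount. The pyridinyl step from compound 1 to compound 2 went in the same direction, somewhat further. Compound 4 is therefore expected to show a modest decrease in this assay, a step of about a 2.5-fold lower number from compound 1 to compound 4 (0.40 log units; beyond the scatter). The estimate for compound 4 in this assay is 120 nM, with a range from 55 nM to 260 nM.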

Compound 4, half-maximal inhibitory concentration: 60 nM
Beside the measured number, compound 4's estimate is 2.0-fold (0.30 log units) above it, within the range that was stated.
By their numbers in this assay, from the lowest: compounds 4, 2 and 3 (each within the scatter of the next); then compound 1.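

In this assay, a third replacement of 4-chlorophenyl on the carbonyl carbon, this time the five-membered non-aromatic pyrrolidin-3-yl, gives the step of a 5.0-fold lower number from compound 1 to compound 4 (0.70 log units; beyond the scatter) and goes the same way as the other two, so compound 1 now stands apart from all three of the other compounds, with none going against this. The new group is not separated from the other two replacements, since both the step of a 2.0-fold lower number from compound 3 to compound 4 (0.30 log units; within the scatter) and the step of a 1.3-fold lower number from compound 2 to compound 4 (0.12 log units; within the scatter) lie within the scatter, and the assay therefore draws no distinction among these three nitrogen-bearing rings at this position. Nothing measured here explains why these replacements lower the number.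

The compounds shown leave open whether the ring nitrogen matters at all, as a plain cyclopentyl or unsubstituted phenyl group on this carbonyl carbon would test that directly. They also leave open whether the defined stereocentre of pyrrolidin-3-yl counts, which the opposite mirror-image form of the group would settle.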